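Benzyl sulfone series: from compound 1 toward compound 4

This account rests on a few compounds, and the source may have more. Where it says the series, first, only, none or still open, it means among the compounds named here.

compound 1 `Cc1ccc(C)c(/C=C(\C(=O)c2ccc(Br)cc2)S(=O)(=O)Cc2ccc(F)cc2)c1`: 1000 nM
compound 2 `CCOc1ccc(/C=C(\C(=O)c2ccc(Br)cc2)S(=O)(=O)c2ccc(Br)cc2)c(OCC)c1`: 10000 nM
compound 3 `Cc1cc(C)cc(/C=C(\C(=O)c2ccc(Cl)cc2)S(=O)(=O)c2ccc(Br)cc2)c1`: 10000 nM

In a functional assay on DU-145 cells (Homo sapiens) for inhibition, read by trypan blue exclusion, with a stated time of 96 h (a higher number here means a weaker inhibitor of growth, a lower number a stronger inhibitor of growth), compound 1 stands lowest of the three numbers; compound 2 and compound 3 each lie higher than compound 1 by a gap that is beyond the scatter. Compound 4 `O=C(/C(=C\c1ccc(Br)cc1)S(=O)(=O)Cc1ccc(F)cc1)c1ccc(Br)cc1` has not yet been measured. It differs from compound 1 in a single place: 4-bromophenyl in place of 2,5-dimethylphenyl on a double-bonded chain carbon bound to a double-bonded chain carbon. Among the compounds with values here, no pair of measured compounds isolates this change, so the expectation rests on compound 1 alone, and the direction is open. A modest step is expected, toward a somewhat higher number or none beyond the scatter; the expected step is a 1.5-fold higher number from compound 1 to compound 4 (0.18 log units; within the scatter). Compound 4 is estimated at about 1500 nM, with a range from 400 nM to 6000 nM.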

Compound 4, concentration for 50% growth inhibition: 25000 nM
The estimate for compound 4 lay 17-fold (1.22 log units) below the measured number; the whole stated range lies below it.
By their numbers in this assay, from the lowest: compound 1; then compounds 2 and 3 (each within the scatter of the next); then compound 4.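

In this assay, the double-bonded chain carbon bound to a double-bonded chain carbon proves sensitive to its aryl group: 4-bromophenyl in place of 2,5-dimethylphenyl gives a 25-fold higher number from compound 1 to compound 4 (1.40 log units; beyond the scatter). This large step occurs although both groups have one six-membered aromatic ring of carbon only, no hydrogen-bond donors or acceptors, and no net charge. No measurement on hand bears on the reason for the step.

As far as these compounds go, it remains open whether the loss comes from introducing 4-bromophenyl or from removing 2,5-dimethylphenyl. From the compounds shown here alone, how a phenyl ring carrying an amine or a carboxylic acid would behave at this place also remains open.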